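This account rests on a few compounds, and the source may have more. Where it says the series, first, only, none or still open, it means among the compounds named here.

Compound 3 `CCCN1CCc2c(sc(NC(=O)Nc3ccc(Cl)cc3)c2C(N)=O)C1` stands at the top of the two numbers in hand: in a functional assay (strain AB) with Danio rerio as the target, read by microscopy, with a stated time of 1 h (on this read-out lower numbers stand for an effect already at smaller amounts and higher numbers for an effect only at larger amounts of compound), compound 3 gives 3500 nM. Compound 2 `NC(=O)c1c(NC(=O)Nc2ccc(Cl)cc2)sc2c1CCN(CCCNC(=O)CCc1cccnc1)C2` gives 470 nM in this assay, and the step of a 7.4-fold higher number from compound 2 to compound 3 (0.87 log units; beyond the scatter) lies beyond the scatter. Compound 1 `CC(C)(C)OC(=O)CN1CCc2c(sc(NC(=O)Nc3ccc(Cl)cc3)c2C(N)=O)C1` gives only a limit in this assay, > 25000 nM, sitting at the limit of > 25000 nM in this assay, at which 1 of the 3 values shown sits. The step of an at least 7.1-fold lower number from compound 1 to compound 3 (0.85 log units; beyond the scatter) is also beyond the scatter.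

Compound 4 `CC(C)(C)OC(=O)CCN1CCc2c(sc(NC(=O)Nc3ccc(Cl)cc3)c2C(N)=O)C1` is not yet measured; its change from compound 3 reads (tert-butoxycarbonyl in place of methyl on a saturated chain carbon, two bonds along the chain from an amine nitrogen in a ring). Of the measured steps, an at least 7.1-fold lower number from compound 1 to compound 3 (0.85 log units; beyond the scatter) bears most directly on it: that step takes the same tert-butoxycarbonyl group away from a saturated chain carbon bound to an amine nitrogen in a ring, whereas compound 4 brings the group back one bond further out. A rise in the number is therefore expected, a 3.4-fold higher number from compound 3 to compound 4 (0.54 log units; beyond the scatter), though the change cut one bond further out leaves room for a smaller shift than the measured one. Compound 4 is estimated at 12000 nM, within 4000 nM to 40000 nM, with a fair chance that only a limit is reported.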

Compound 4, half-maximal effective concentration: 1100 nM
The estimate for compound 4 lay 11-fold (1.04 log units) above the measured number; measured number below the stated range.
By their numbers in this assay, from the lowest: compound 2; then compound 4; then compound 3. At a limit, above all of these: compound 1.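

In this assay, tert-butoxycarbonyl on a saturated chain carbon, two bonds along the chain from an amine nitrogen in a ring, lowers the number relative to the plain propyl chain (a 3.2-fold lower number from compound 3 to compound 4 (0.50 log units; beyond the scatter)), though the result does not reach the level of the pyridine-bearing amide chain (a 2.3-fold higher number from compound 2 to compound 4 (0.37 log units; beyond the scatter)). Moving from tert-butoxycarbonyl on the carbon bound to the ring nitrogen to the 2-(tert-butoxycarbonyl)ethyl chain has a large effect (an at least 22-fold lower number from compound 1 to compound 4 (1.35 log units; beyond the scatter)), so the distance of this group from the ring nitrogen matters in this pair. The value of compound 1 is a limit, not a number: the limit of > 25000 nM in this assay, at which 1 of the 4 values shown sits.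

Open, from the compounds shown here alone, is whether a carboxylic acid or a primary amide at the same place would keep the lower number of compound 4. Also open, going by these compounds, is how a longer chain carrying tert-butoxycarbonyl would read.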